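The source may hold more compounds than are shown below. What is called first, only, known or untested is meant among the compounds shown, and "the series" means these compounds.

Compound 2 `CCNC(=O)C1=C(C)NC(=O)NC1c1ccoc1` belongs to a set of three compounds built on a shared core. In an assay on membranes from HeLa cells for displacement of a labelled ligand from adenosine receptor A3 (Homo sapiens), read by scintillation counting, with a stated time of 180 min, tested at 1 uM (on this read-out higher numbers stand for more inhibition at the one concentration tested (going by the name of the read-out) and lower numbers for less inhibition), compound 2 gives 1%. Compound 1 `CCCC(=O)C1=C(C)NC(=O)NC1c1ccoc1` gives 2%, and compound 3 `CC1=C(c2ncc(C)o2)C(c2ccoc2)NC(=O)N1` gives 1%. The steps of a number 1 percentage points lower from compound 1 to compound 2 (within the scatter), no change at the digits printed from compound 2 to compound 3 (within the scatter) and a number 1 percentage points lower from compound 1 to compound 3 (within the scatter) all lie within the scatter, so compound 2 stands level with compound 3 and with compound 1, and none of the three can be ranked. Compound 4 `CC1=C(C(=O)OC2CCCC2)C(c2ccoc2)NC(=O)N1` differs from compound 2 by cyclopentyloxy in place of ethylamino on a carbonyl carbon. The step of a number 1 percentage points lower from compound 1 to compound 2 (within the scatter), which also exchanges groups on that carbonyl carbon, bears on this change and was within the scatter, so no step beyond the scatter is expected in this assay, giving a number 1 percentage points higher from compound 2 to compound 4 (within the scatter). Compound 4 is therefore estimated at 2%, with a range from 0% to 12%.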

Compound 4, a percentage reported as inhibition, at one concentration (the size of the read-out at that concentration, not a potency): 1%
The estimate for compound 4 lay 1 percentage points above the measured number, and the stated range covers the measured number.
By their numbers in this assay, from the lowest: compounds 2, 3, 4 and 1 (each within the scatter of the next).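

Putting cyclopentyloxy on the carbonyl carbon in place of ethylamino gives no change at the digits printed from compound 2 to compound 4 (within the scatter), and putting it there in place of propyl gives a number 1 percentage points lower from compound 1 to compound 4 (within the scatter). In this assay, an ester bearing a five-membered carbon ring therefore cannot be told apart from the amide or the ketone at this position, and all four compounds remain unranked. Nothing measured here offers an explanation for these numbers. As far as these compounds go, whether a carboxylic acid, a phenyl ester or a piperidine amide on this carbonyl carbon would move the number beyond the scatter stays open.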